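A few compounds are considered here, and "the series" means these few. Any claim that something is new, unique, unknown or untested is made for them only; others in the source may bear on it.

The measured compounds:
compound 1, `O=C(N/N=C/c1cccc(Br)c1)Nc1cc2c(Nc3ccc(F)c(Cl)c3)ncnc2cc1O[C@H]1CCOC1` — 12400 nM
compound 2, `CC(C)(C)c1cc(/C=N/NC(=O)Nc2cc3c(Nc4ccc(F)c(Cl)c4)ncnc3cc2O[C@H]2CCOC2)cc(C(C)(C)C)c1O` — 14500 nM
compound 3, `COc1cc2ncnc(Nc3ccc(F)c(Cl)c3)c2cc1NC(=O)N/N=C/c1cccc(Br)c1` — 27100 nM

All three were tested in a functional assay on MCF7 cells (Homo sapiens) for cytotoxicity, read by MTT assay, with a stated time of 72 h; a lower number here means a stronger inhibitor, a higher number a weaker inhibitor. Compound 3 gives the highest number of the three. Its nearest neighbour is compound 2, and the two values lie within the scatter of each other, so no order can be read between them. Compound 1 stands further off: a 2.2-fold higher number from compound 1 to compound 3 (0.34 log units; beyond the scatter), a modest step that comes from a change at the oxygen on the aromatic ring, not at the aryl group of the hydrazone.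

Compound 4, `COc1cc2ncnc(Nc3ccc(F)c(Cl)c3)c2cc1NC(=O)N/N=C/c1cc(Br)c(O)c(Br)c1`, keeps the core of compound 3 and alters only the aryl group: 3,5-dibromo-4-hydroxyphenyl in place of 3-bromophenyl on a carbon with a double bond to nitrogen.

Among the measured compounds shown here, no measured step addresses this change directly; the one recorded step concerns methyl in place of oxolan-3-yl. Compounds 1 and 2 differ from each other only in that aryl group, and in this assay compound 1 gives 12400 nM while compound 2 gives 14500 nM, values within the scatter of each other. The aryl group therefore appears to carry little weight, and no step beyond the scatter is expected here.

Compound 4 is accordingly estimated at 25000 nM, between 10000 nM and 60000 nM. For compound 4 the expected step is a 1.1-fold lower number from compound 3 to compound 4 (0.04 log units; within the scatter), within the scatter.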

Compound 4, half-maximal inhibitory concentration: 30200 nM
For compound 4 the middle estimate is 1.2-fold (0.08 log units) below the measured one, within the range that was stated.
By their numbers in this assay, from the lowest: compounds 1, 2, 3 and 4 (each within the scatter of the next, the first and the last beyond it).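

In this assay, putting 3,5-dibromo-4-hydroxyphenyl in place of 3-bromophenyl on a carbon with a double bond to nitrogen gives a 1.1-fold higher number from compound 3 to compound 4 (0.05 log units; within the scatter), so no order can be read between the two compounds, although the entering group brings a second bromine and a hydroxyl. Until now, the aryl group had been varied only with oxolan-3-yl on the oxygen on the aromatic ring, where compound 1 gives 12400 nM and compound 2 gives 14500 nM; this pair shows that a change of aryl group also leaves the number within the scatter with methyl on that oxygen. No measurement shown here offers an explanation for this result.

The second bromine and the hydroxyl enter together, so the compounds shown cannot tell what each does alone, or whether their contributions cancel. On these data alone, it also remains open whether this position would stay as unresponsive with an aryl group carrying an amine or a carboxylic acid, or with a saturated ring such as morpholine in place of the aryl group.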